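This account rests on a few compounds, and the source may have more. Where it says the series, first, only, none or still open, it means among the compounds named here.

Compound 1 `O=C(Nc1cccc(OCCc2ccccn2)c1)C1CCCN(C(=O)c2cc(C(F)(F)F)cc(C(F)(F)F)c2)C1`: 5%
Compound 2 `O=C(Nc1cccc(Cc2ccccc2)c1)C1CCCN(C(=O)c2cc(C(F)(F)F)cc(C(F)(F)F)c2)C1`: 0%

Both compounds were tested in an ADME assay on PC-3 cells (Homo sapiens) for cytotoxicity, read by WST assay, tested at 100 uM; on this read-out higher numbers stand for more inhibition at the one concentration tested (going by the name of the read-out) and lower numbers for less inhibition. Compound 2 holds the lower of the two numbers, but its nearest neighbour compound 1 sits close: the step of a number 5 percentage points lower from compound 1 to compound 2 (within the scatter) is within the scatter. Compound 3 `O=C(Nc1cccc(Oc2ccccc2)c1)C1CCCN(C(=O)c2cc(C(F)(F)F)cc(C(F)(F)F)c2)C1` is not yet measured. Its change from compound 2 is phenoxy in place of benzyl on an aromatic carbon. For the measured compounds named here, the one measured step, a number 5 percentage points lower from compound 1 to compound 2 (within the scatter), swapped a group at the same aromatic carbon without moving beyond the scatter, and no measured step involves phenoxy. For compound 3 the expected step is a number 3 percentage points higher from compound 2 to compound 3 (within the scatter), none beyond the scatter. Compound 3 is therefore estimated at 3%, from 0% to 15%.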

Compound 3, a percentage reported as inhibition, at one concentration (the size of the read-out at that concentration, not a potency) in the PC-3 assay: 1%
Compound 3: middle estimate off by 2 percentage points, on the high side; the measured number falls inside the stated range.
By their numbers in the PC-3 assay, from the lowest: compounds 2, 3 and 1 (each within the scatter of the next).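

In the PC-3 assay phenoxy on this aromatic carbon cannot be told apart from benzyl (a number 1 percentage points higher from compound 2 to compound 3 (within the scatter)) or from 2-(pyridin-2-yl)ethoxy (a number 4 percentage points lower from compound 1 to compound 3 (within the scatter)), so all three groups read alike at this position. In a physicochemical assay for solubility, measured as kinetic solubility (on this read-out higher numbers stand for higher solubility and lower numbers for lower solubility), compound 2 gives 1.89 ug/mL and compound 3 gives 3.22 ug/mL and the step between them (a 1.7-fold higher number from compound 2 to compound 3 (0.23 log units; within the scatter)) also shows no real separation. Nothing available explains these results.

Going by these compounds, whether an amine or a carboxylic acid on this aromatic carbon would separate from these three groups in the PC-3 assay stays open. How such a group would read in the physicochemical assay is open too.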